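Swapping the Ring on a Chain Tail of a Dead Compound

This account rests on a few compounds, and the source may have more. Where it says the series, first, only, none or still open, it means among the compounds named here.

Measured compounds:
Compound 1, `O=C1O/C(=C\Cn2ncc(=O)[nH]c2=O)C(OCc2ccccc2)=C1OCc1ccccc1`: 45000 nM
Compound 2, `NC1(CCn2ccc(=O)[nH]c2=O)OC(=O)C(OCc2ccccc2)=C1OCc1ccccc1`: > 100000 nM

In a functional assay on HeLa cells (Homo sapiens) for inhibition, read by MTT assay, with a stated time of 72 h (on this read-out higher numbers stand for weaker inhibition and lower numbers for stronger inhibition), compound 1 gives 45000 nM. Compound 2 reaches only the limit of this assay, > 100000 nM, and no number is reported for it. Compound 2 therefore sits at the weak end of what is shown, with one of the two values at that limit (the limit of > 100000 nM in this assay, at which 1 of the 2 values shown sits); no step between the two measured compounds is drawn, since they differ in more than one place.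

Compound 3, `NC1(CCn2c(=O)[nH]c(=O)[nH]c2=O)OC(=O)C(OCc2ccccc2)=C1OCc1ccccc1`, has not yet been measured. It differs from compound 2 by a group of 9 heavy atoms (3 carbon, 3 nitrogen, 3 oxygen; one six-membered aromatic ring with 3 hetero atoms) in place of a group of 8 heavy atoms (4 carbon, 2 nitrogen, 2 oxygen; one six-membered aromatic ring with 2 hetero atoms), on a saturated chain carbon, two bonds along the chain from a saturated ring carbon. Going by the values given here, no measured step tells how such a change behaves here, and nothing among the data says whether compound 3 should improve on compound 2. The account rests on compound 2 alone, whose value in this assay is a limit, so compound 3 is expected to stay near that limit, the step from compound 2 to compound 3 being estimated as a number no higher from compound 2 to compound 3 (the limit leaves the size open). Compound 3 is thus expected to give about 100000 nM, within 40000 nM to 300000 nM, and may well return only a limit.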

Compound 3, half-maximal inhibitory concentration: 77100 nM
The estimate for compound 3 lay 1.3-fold (0.11 log units) above the measured number; measured number inside the range.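

Going by these compounds alone, the tail on this chain is the first place where a single change can be read, and it shows that the position responds to the ring it carries. With the group of 9 heavy atoms (one six-membered aromatic ring with 3 hetero atoms) in place of the group of 8 heavy atoms (one six-membered aromatic ring with 2 hetero atoms), on a saturated chain carbon, two bonds along the chain from a saturated ring carbon, this assay gives an at least 1.2-fold lower number from compound 2 to compound 3 (0.11 log units; that floor lies within the scatter). The value of compound 2 is a limit and not a number, so the true size of this step stays open, and only its floor can be stated, because the comparison starts from that limit: the limit of > 100000 nM in this assay, at which 1 of the 3 values shown sits.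

The compounds shown leave open whether a carboxylic acid in place of the ring, or a longer chain carrying the same ring, would move the number further at this position. They also leave open whether the same ring swap would behave alike on the core of compound 1, whose tail differs from these in more than one place.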